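The source may hold more compounds than are shown below. What is called first, only, known or untested is meant among the compounds shown, and "the series" means these compounds.

Compound 1 `Cc1cc(Nc2cc(-c3ccccc3)[nH]n2)n2nc(SCCc3ccccc3)nc2n1` gives 5620 nM in a functional assay on MGC-803 cells (Homo sapiens) for inhibition, read by MTT assay, with a stated time of 72 h; a lower number here means a stronger inhibitor, a higher number a weaker inhibitor.
Compound 2 `Cc1cc(Nc2cc(-c3ccccc3)[nH]n2)n2nc(SCc3ccc(C(F)(F)F)cc3)nc2n1` gives 3520 nM in this assay.
Compound 3 `Cc1cc(Nc2cc(-c3ccccc3)[nH]n2)n2nc(SCC3CC3)nc2n1` gives 16100 nM in this assay.

Compound 3 has the highest number of the three, so it is the weakest inhibitor here. Both steps leading to it lie beyond the scatter: a 2.9-fold higher number from compound 1 to compound 3 (0.46 log units; beyond the scatter) and a 4.6-fold higher number from compound 2 to compound 3 (0.66 log units; beyond the scatter). Compound 4 `Cc1cc(Nc2cc(-c3ccccc3)[nH]n2)n2nc(SCC3CCCCC3)nc2n1` shares the core of compound 3 and differs from it in one place: cyclohexyl in place of cyclopropyl on a saturated chain carbon bound to a sulfur. The two steps that bear on this change are those into compound 3, where a cyclopropyl replaced a larger group and the number rose modestly each time. Compound 4 goes the other way, to a larger ring, though one of a different kind than in compounds 1 and 2, so a modest drop in the number is expected, with the estimated step of a 2.3-fold lower number from compound 3 to compound 4 (0.36 log units; beyond the scatter). Compound 4 is therefore estimated at 7000 nM in this assay, with a likely range from 3000 nM to 17000 nM.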

Compound 4, half-maximal inhibitory concentration: 12600 nM
Beside the measured number, compound 4's estimate is 1.8-fold (0.26 log units) below it, within the range that was stated.
By their numbers in this assay, from the lowest: compounds 2 and 1 (each within the scatter of the next); then compounds 4 and 3 (each within the scatter of the next).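

In this assay, the change from cyclopropyl to cyclohexyl on a saturated chain carbon bound to a sulfur gives a 1.3-fold lower number from compound 3 to compound 4 (0.11 log units; within the scatter), so the larger saturated ring does not separate these two compounds. Cyclohexyl in place of the other groups gives a 3.6-fold higher number from compound 2 to compound 4 (0.55 log units; beyond the scatter) and a 2.2-fold higher number from compound 1 to compound 4 (0.35 log units; beyond the scatter), so in these four compounds the benzyl and 4-(trifluoromethyl)phenyl groups give lower numbers than either saturated ring, with no compound going against this. Nothing available explains this difference between the groups.

The compounds shown leave open whether a benzyl ring carrying a hydroxyl or an amine would keep the lower numbers. They also leave open how a pyridine ring or a longer chain ending in a carboxylic acid would behave at this position.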